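The source may report more compounds than this note shows. Statements on the series, on what has been measured and on what is new or still open speak of the compounds shown alone.

Measured compounds:
- compound 1, `CCOC(=O)C1=C(C)NC(C)=C(C(=O)OCC)C1c1cnc(SC)n1Nc1ccccc1`, in an assay on isolated protein (strain albino) for antagonist activity at Voltage-dependent L-type calcium channel subunit alpha-1C (Cavia porcellus) (a higher number here means a weaker inhibitor, a lower number a stronger inhibitor), compound 1 gives 1.69 nM
- compound 2, `CCOC(=O)C1=C(C)NC(C)=C(C(=O)OC)C1c1cnc(SC)n1Nc1ccccc1`, in this assay compound 2 gives 1.66 nM

Compound 2 shows the lowest of the two numbers measured in this assay, but its nearest neighbour is compound 1, and the step of a 1.0-fold lower number from compound 1 to compound 2 (0.01 log units; within the scatter) lies within the scatter, so the two compounds cannot be told apart.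

Compound 3, `COC(=O)C1=C(C)NC(C)=C(C(=O)OCc2ccccc2)C1c1cnc(SC)n1Nc1ccccc1`, has not yet been measured. It differs from compound 2 by phenyl in place of methyl on a saturated chain carbon bound to an oxygen next to a carbonyl group. Among the compounds with values here, the only measured step touches the same place: the change from compound 1 to compound 2 also altered the ester chain there, and it was a 1.0-fold lower number from compound 1 to compound 2 (0.01 log units; within the scatter). That step replaced one small alkyl group with a smaller one and shows that the place tolerates at least this change with no effect beyond the scatter. The move to benzyl is larger than anything measured, so the expectation rests on a single step and is uncertain.

Compound 3 is therefore expected to give roughly 2 nM in this assay, with a plausible range from 0.6 nM to 7 nM. The step from compound 2 to compound 3 is expected to be a 1.2-fold higher number from compound 2 to compound 3 (0.08 log units; within the scatter).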

Compound 3, half-maximal inhibitory concentration: 2.21 nM
Compound 3: the middle estimate sits 1.1-fold (0.04 log units) below what was measured, and the stated range covers the measured number.
By their numbers in this assay, from the lowest: compounds 2, 1 and 3 (each within the scatter of the next).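

In this assay, the change of ethyl to benzyl at this saturated chain carbon bound to an oxygen next to a carbonyl group gives a 1.3-fold higher number from compound 2 to compound 3 (0.12 log units; within the scatter). Within the data shown here, the earlier step, a 1.0-fold lower number from compound 1 to compound 2 (0.01 log units; within the scatter), had exchanged only one small alkyl group for another, whereas this one brings in a phenyl with its six-membered aromatic ring and still cannot be told apart from the scatter, so the place accepts a far larger ester chain than the earlier compounds showed. Nothing available accounts for this tolerance.

What the compounds shown leave open is whether the same place accepts an ester chain that carries an amine or a carboxylic acid rather than only carbon, and whether a longer chain ending in phenyl behaves as benzyl does. Among these compounds, they also leave open whether a substituent such as fluorine or methoxy on the phenyl itself would give a step beyond the scatter, since the only aromatic group tested at this place is the unsubstituted one.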